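Swapping the fluorophenyl on compound 2 for a cyclopropylcarbonyl

A few compounds are considered here, and "the series" means these few. Any claim that something is new, unique, unknown or untested is made for them only; others in the source may bear on it.

Three compounds share a core in which a nitrile-bearing aromatic ring is joined to a saturated ring with two nitrogens. Compound 1 `Cn1cc(-c2ncc(C#N)c(N3CCN(c4cccc(F)c4)CC3)n2)cn1` gives 3.2 in a physicochemical assay for lipophilicity, read by HPLC; on this read-out higher numbers stand for higher lipophilicity and lower numbers for lower lipophilicity. Compound 2 `C[C@@H]1CN(c2nc(-c3cnn(C)c3)ncc2C#N)CCN1c1cccc(F)c1` gives 3.3 in this assay, and the step of a number 0.10 log units higher from compound 1 to compound 2 (within the scatter) shows that adding that methyl changed little. Compound 3 `N#Cc1cnc(-c2ccccc2)nc1N1C[C@@H]2C[C@H]1CN2c1cccc(F)c1` gives 4.5 in this assay; it differs from compound 2 in more than one place, so it only shows where a distinct compound lands. Among the three numbers compound 2 stands second highest, close to compound 1 and well below compound 3.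

Compound 4 `C[C@@H]1CN(c2nc(-c3cnn(C)c3)ncc2C#N)CCN1C(=O)C1CC1` has not been measured. It differs from compound 2 by cyclopropylcarbonyl in place of 3-fluorophenyl on an amine nitrogen in a ring. Among the compounds with values here, no measured step covers this exchange: the one step in hand, from compound 1 to compound 2, concerns a methyl and lay within the scatter. What the change itself shows is that a group with no hydrogen-bond acceptor leaves and a smaller group with one acceptor enters, which is expected to lower the number. The expected step is a number 1.70 log units lower from compound 2 to compound 4 (beyond the scatter) in this assay. For compound 4 the estimate in this assay is 1.6, with a range from 1 to 2.3.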

Compound 4, distribution coefficient: 1.5
Compound 4: the middle estimate sits 0.10 log units above what was measured, and the stated range covers the measured number.
By their numbers in this assay, from the lowest: compound 4; then compounds 1 and 2 (each within the scatter of the next); then compound 3.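

On the amine nitrogen in the ring, the choice of group proves far more consequential in this assay than the methyl on the saturated ring carbon: that earlier change gave a number 0.10 log units higher from compound 1 to compound 2 (within the scatter) whereas cyclopropylcarbonyl in place of 3-fluorophenyl gave a number 1.80 log units lower from compound 2 to compound 4 (beyond the scatter) on this one exchange. The exchange removes a six-membered aromatic ring, adds a three-membered ring and brings in a carbonyl all at once, and this single step cannot divide the shift among those parts. Nothing measured here explains the size of the shift. 

The compounds shown leave open where a cyclopropylmethyl group, which keeps the three-membered ring without the carbonyl, would land on this nitrogen. On these data alone, an acetyl group there, which keeps the carbonyl without that ring, remains equally open.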